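Swapping thiophen-2-yl for 2,4-difluorophenyl in a transporter series

The source may report more compounds than this note shows. Statements on the series, on what has been measured and on what is new or still open speak of the compounds shown alone.

Measured compounds:
compound 1 `OC(CCN1CC=C(Cc2ccccc2)CC1)c1cccs1` — 52%
compound 2 `COc1ccc2cc(C(O)CCN3CCC(O)(Cc4ccccc4)CC3)ccc2c1Cl` — 73%

In an assay on CHO cells for inhibition of sodium-dependent dopamine transporter (Homo sapiens), read by scintillation counting, with a stated time of 10 min, tested at 10 uM (on this read-out lower numbers stand for less inhibition and higher numbers for more inhibition at the one concentration tested (going by the name of the read-out)), compound 1 gives 52%, the lower of the two numbers recorded. Compound 2 gives 73% in this assay, a gap that lies beyond the usual scatter, so compound 1 stands clearly under compound 2. For the measured compounds named here, the two compounds differ in several places at once, and no single-change step between measured compounds is available.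

Compound 3 `OC(CCN1CC=C(Cc2ccccc2)CC1)c1ccc(F)cc1F` differs from compound 1 in one place only: 2,4-difluorophenyl in place of thiophen-2-yl on a saturated chain carbon bound to an oxygen on a saturated carbon and a saturated chain carbon. Going by the values given here, since no measured pair shows this change, any expectation rests on compound 1 alone. The step from compound 1 to compound 3 is expected to be small, probably within the scatter, with a slight lean upward: a number 5 percentage points higher from compound 1 to compound 3 (within the scatter). Compound 3 is accordingly estimated at 57% in this assay, with a range from 30% to 82%.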

Compound 3, a percentage reported as inhibition, at one concentration (the size of the read-out at that concentration, not a potency): 66%
For compound 3 the middle estimate is 9 percentage points below the measured one, within the range that was stated.
By their numbers in this assay, from the lowest: compound 1; then compounds 3 and 2 (each within the scatter of the next).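

Replacing thiophen-2-yl with 2,4-difluorophenyl gives a number 14 percentage points higher from compound 1 to compound 3 (beyond the scatter) in this assay and shows that the read-out responds to the group on a saturated chain carbon bound to an oxygen on a saturated carbon and a saturated chain carbon. This is the first step among the compounds shown in which only one place changes, a separation that the comparison of compound 1 with compound 2 could not provide. Nothing available explains why the step occurs.

The step changes the ring and brings in the two fluorines together, so the compounds shown do not tell these contributions apart. Going by these compounds, how a plain phenyl or a 4-fluorophenyl group would read at this place stays open, as does whether the step would carry over to other cores.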